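The compounds below may be only part of what the source reports. "The series", "measured", "known", "first", "only" and "open" are said of these compounds alone.

Compound 2, `NC(=S)Nc1cccc(OCCCCCCCCNC(=S)Nc2cccc(Br)c2)c1`, belongs to a pair of bis-thioureas built on one shared core. Among the measured compounds shown here, in an ADME assay on Huh-7 cells (Homo sapiens) for cytotoxicity (on this read-out lower numbers stand for higher toxicity in this test and higher numbers for lower toxicity in this test), compound 2 gives 20000 nM, which is the higher of the two numbers known so far. For the measured compounds named here, its only neighbour is compound 1, `NC(=S)Nc1cccc(OCCCCCCCCNC(=S)Nc2ccc(Br)cc2)c1`, and in this assay compound 1 gives 18000 nM. The step between them, a 1.1-fold higher number from compound 1 to compound 2 (0.05 log units; within the scatter), shows that moving the bromine around the ring did not change the read-out beyond the scatter.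

Compound 3, `NC(=S)Nc1cccc(OCCCCCCCCNC(=S)Nc2ccccc2Br)c1`, has not yet been measured. It differs from compound 2 in one place: 2-bromophenyl in place of 3-bromophenyl on an amide-type nitrogen. Going by the values given here, the single step that bears on this change is the one just described, and since that step stayed within the scatter, the expected step of no change at the digits printed from compound 2 to compound 3 (within the scatter) is likewise no change beyond the scatter. Compound 3 is therefore expected to give about 20000 nM in this assay, within a range of 9000 nM to 45000 nM.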

Compound 3, half-maximal cytotoxic concentration: 36000 nM
For compound 3 the middle estimate is 1.8-fold (0.26 log units) below the measured one; the range from low to high includes it.
By their numbers in this assay, from the lowest: compounds 1, 2 and 3 (each within the scatter of the next).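

Placed on the amide-type nitrogen, the 2-bromophenyl group completes a set of three bromophenyl isomers that can be read side by side in this assay. The steps, a 1.8-fold higher number from compound 2 to compound 3 (0.26 log units; within the scatter) and a 2.0-fold higher number from compound 1 to compound 3 (0.30 log units; within the scatter) alike, stay within the scatter, so what a single pair suggested now holds across all three compounds: none of the three bromine placements stands apart on this read-out. Nothing at hand offers an explanation for the numbers these three compounds give.

The compounds shown leave open whether a carboxylic acid, an amine or a methoxy group in place of the bromine would also stay within the scatter. They also leave open what a shorter chain in the shared core would do to this read-out.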